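The compounds below may be only part of what the source reports. "The series", "measured", "known", "first", "only" and "open" are said of these compounds alone.

Compound 1 `CC(C)(C)C(=O)Nc1ccc(-c2cccc(C(=O)N[C@H]3CN[C@@H](C(=O)Nc4ccc(Cl)c(C(F)(F)F)c4)C3)c2)cn1` was examined in a functional assay on K562 cells (Homo sapiens) for inhibition, read by MTT assay, with a stated time of 48 h (a lower number here means a stronger inhibitor, a higher number a weaker inhibitor), where compound 1 gives 28000 nM. Compound 2 `Nc1ccc(-c2cccc(C(=O)N[C@H]3CN[C@@H](C(=O)Nc4ccc(Cl)c(C(F)(F)F)c4)C3)c2)cn1` keeps the core of compound 1 and differs from it by hydrogen in place of (tert-butyl)carbonyl on a nitrogen on an aromatic ring. In this assay compound 2 gives 20000 nM, so the step of a 1.4-fold lower number from compound 1 to compound 2 (0.15 log units; within the scatter) stays inside the usual scatter of this kind of measurement. Compound 3 `C[C@H](NC(=O)c1cccc(-c2ccc(NC(=O)C(C)(C)C)nc2)c1)C(=O)Nc1ccc(Cl)c(C(F)(F)F)c1` carries the same ((tert-butyl)carbonyl)amino group on a different core; the difference between the two cores is not broken down here. In this assay compound 3 gives 18400 nM, and the three values of compound 1, compound 2 and compound 3 all lie within the scatter of one another. Compound 4 `C[C@H](NC(=O)c1cccc(-c2ccc(N)nc2)c1)C(=O)Nc1ccc(Cl)c(C(F)(F)F)c1` has no measurement in hand. It differs from compound 3 by hydrogen in place of (tert-butyl)carbonyl on a nitrogen on an aromatic ring, the same change as between compound 1 and compound 2, and the place of the change is described in the same words in both pairs. Because the step of a 1.4-fold lower number from compound 1 to compound 2 (0.15 log units; within the scatter) did not move the number beyond the scatter, the expected step for the same change on the core of compound 3 is a 1.3-fold lower number from compound 3 to compound 4 (0.12 log units; within the scatter). Compound 4 is therefore estimated to give about 14000 nM in this assay, with the expected range running from 6000 nM to 35000 nM.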

Compound 4, half-maximal inhibitory concentration: 8090 nM
Estimate against measurement, compound 4: 1.7-fold (0.24 log units) above; low and high end bracket the measured number.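

Replacing the (tert-butyl)carbonyl with hydrogen on a nitrogen on an aromatic ring gives, in this assay, a 2.3-fold lower number from compound 3 to compound 4 (0.36 log units; beyond the scatter), a modest step that lies beyond the scatter, whereas the same change on the other core, a 1.4-fold lower number from compound 1 to compound 2 (0.15 log units; within the scatter), stays inside it. Set side by side, the two steps cannot be told apart, so this pair of cores gives no sign that the core alters what the change does: the same change on two cores in this assay, a 1.4-fold lower number (0.15 log units; within the scatter) from compound 1 to compound 2 and a 2.3-fold lower number (0.36 log units; beyond the scatter) from compound 3 to compound 4, 1.6-fold (0.21 log units) apart, within the scatter of two such steps This supports carrying the size of the step from one of these cores to the other, but it does not show that the change has a real effect on both cores, since only the step on the core of compound 3 stands clear of the scatter, and two pairs cannot establish a rule for the series.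

The compounds shown leave open what lies between the free amino group and the ((tert-butyl)carbonyl)amino group, such as an acetyl or a methyl group on the same nitrogen, or a longer acyl chain in place of the (tert-butyl)carbonyl. They also leave open whether the step would hold on a third core, or with a carboxylic acid in place of the amino group.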